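Configuration-only step within the lactone series

The compounds below may be only part of what the source reports. "The series", "measured", "known", "first", "only" and "open" are said of these compounds alone.

Numbers come from a functional assay on A2780 ADR cells (Homo sapiens) for cytotoxicity, read by MTT assay, with a stated time of 24 h; on this read-out higher numbers stand for weaker inhibition and lower numbers for stronger inhibition.
compound 1, `CCCCC[C@@H](C[C@H](O)C[C@@H]1CC=CC(=O)O1)OC`: 26300 nM
compound 2, `CCCCC[C@@H](CCC[C@H]1CC=CC(=O)O1)OC`: 9000 nM
compound 3, `CCCCC[C@H](C[C@H](O)C[C@@H]1CC=CC(=O)O1)OC`: 30000 nM

Compound 3 gives the highest number of the three. Its nearest neighbour is compound 1, which differs only in configuration: a 1.1-fold higher number from compound 1 to compound 3 (0.06 log units; within the scatter). Going by the values given here, compound 2 stands furthest from compound 3, with a lower number in this assay that lies beyond the scatter; no single-point step links compound 2 to compound 3.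

Compound 4, `CCCCC[C@@H](C[C@H](O)C[C@H]1CC=CC(=O)O1)OC`, has not been measured in this assay. Relative to compound 3 the change is the two compounds have the same atoms and bonds and differ only in configuration as drawn: 2 of 3 stereo elements differ; a stereocentre at a saturated chain carbon is drawn R in compound 3 and S in compound 4; a stereocentre at a saturated ring carbon is drawn S in compound 3 and R in compound 4.

Among the compounds with values here, the one measured step that bears on this is the configuration-only step from compound 1 to compound 3, which stayed within the scatter, as the two compounds differ only in configuration (the fact that compounds 1 and 3 differ only in the configuration as drawn). On that basis no step beyond the scatter is expected for compound 4; the change counts two stereo elements rather than one, which widens the range but gives no direction. The expected step is a 1.2-fold lower number from compound 3 to compound 4 (0.06 log units; within the scatter). In this assay compound 4 is estimated at 26000 nM, with a range from 9000 nM to 70000 nM.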

Compound 4, half-maximal inhibitory concentration: 48000 nM
Estimate against measurement, compound 4: 1.8-fold (0.27 log units) below, within the range that was stated.
By their numbers in this assay, from the lowest: compound 2; then compounds 1, 3 and 4 (each within the scatter of the next).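

Inverting the saturated ring carbon alone gives no change that can be read in this assay, with a 1.8-fold higher number from compound 1 to compound 4 (0.26 log units; within the scatter): the fact that compounds 1 and 4 differ only in the configuration as drawn Inverting that carbon together with the saturated chain carbon also stays inside the usual scatter, with a 1.6-fold higher number from compound 3 to compound 4 (0.20 log units; within the scatter): the fact that compounds 3 and 4 differ only in the configuration as drawn The only new step beyond the scatter is the modest one with hydroxy in place of hydrogen on a saturated chain carbon bound to two saturated chain carbons, a 5.3-fold higher number from compound 2 to compound 4 (0.73 log units; beyond the scatter), so among these new steps the hydroxy exchange, not the configuration, goes with the larger difference.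

Going by these compounds, the effect of inverting the third stereo element remains open. Also open, on these data alone, is how an amine or an acetate ester in place of the hydroxy, or a longer chain, would read in this assay.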